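The compounds below may be only part of what the source reports. "The series", "measured", "known", "first", "only" and "open" are said of these compounds alone.

Measured compounds:
Compound 1 `CNCc1cc(-c2cccnc2F)n(S(=O)(=O)c2cccnc2)c1` — 96%
Compound 2 `CNCc1cn(S(=O)(=O)c2cccnc2)c(-c2cccnc2F)c1C` — 93%

In a functional assay on the whole organism (strain Jcl:SD) for inhibition, with Rattus norvegicus as the target, with stated times of 3 min and 3 h, at a dose of 1 mg/kg by the intravenous route (on this read-out lower numbers stand for less inhibition and higher numbers for more inhibition at the one dose given (going by the name of the read-out)), compound 1 gives 96% and compound 2 gives 93%. The step of a number 3 percentage points lower from compound 1 to compound 2 (within the scatter) leaves the two compounds within the scatter of each other, so neither number can be called the higher or the lower of the pair. Compound 2 holds the lowest of the two numbers shown, with compound 1 the nearest and within the scatter.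

Compound 3 `CNCc1cn(S(=O)(=O)c2cccnc2)c(-c2cccnc2F)c1Cl` has not been measured in this assay. It differs from compound 2 by chloro in place of methyl on an aromatic carbon. Within the data shown here, the one measured step, from compound 1 to compound 2, touched the same aromatic carbon but exchanged hydrogen for methyl, and it stayed within the scatter. Among the measured compounds shown here, no measured step exchanges methyl for chloro, so nothing among the measured compounds points to a shift beyond the scatter in either direction. Compound 3 is therefore expected to stay close to compound 2, with an estimated step of a number 3 percentage points lower from compound 2 to compound 3 (within the scatter). The estimate for compound 3 in this assay is 90%, with a range from 75% to 99%.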

Compound 3, a percentage reported as inhibition, in the whole organism at one dose (the size of the read-out at that dose, not a potency) in the Rattus norvegicus assay: 95%
Estimate against measurement, compound 3: 5 percentage points below, and the stated range covers the measured number.
By their numbers in the Rattus norvegicus assay, from the lowest: compounds 2, 3 and 1 (each within the scatter of the next).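

With chloro on this aromatic carbon, hydrogen, methyl and chloro can now all be compared in the Rattus norvegicus assay: the result is a number 2 percentage points higher from compound 2 to compound 3 (within the scatter) and a number 1 percentage points lower from compound 1 to compound 3 (within the scatter), so the three compounds cannot be put in an order, and this position has so far accepted all three at the one dose given. Among these compounds, what the earlier compounds did not show is that the same exchange can register on another read-out: in a physicochemical assay for lipophilicity, read by HPLC, at pH 7.4 (on this read-out lower numbers stand for lower lipophilicity and higher numbers for higher lipophilicity), compound 2 gives -0.4 and compound 3 gives 0.48, which is a number 0.88 log units higher from compound 2 to compound 3 (beyond the scatter). Chloro in place of methyl therefore shifts the distribution coefficient beyond the scatter while the inhibition stays within it, so for this pair the two read-outs do not move together.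

Going by these compounds, whether a methoxy group, a nitrile or a carboxylic acid on this aromatic carbon would keep the inhibition remains open, as does how far the distribution coefficient could move before the inhibition followed. A single dose also leaves open whether compound 1, compound 2 and compound 3 would separate at lower doses.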